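The source may report more compounds than this note shows. Statements on the series, on what has been measured and on what is new or still open speak of the compounds shown alone.

For the measured compounds named here, compound 2 `CCOc1ccc(NC(=O)Nc2cc(C(C)(C)C)nn2-c2ccccc2)cc1` stands lowest of the two numbers in an assay on isolated protein for inhibition of STE20-like serine/threonine-protein kinase (Homo sapiens), read by thermal shift assay, tested at 10 uM; a higher number here means that the compound stabilises the target more against heat, a lower number that the compound stabilises the target less: compound 2 gives 1.1 degrees C, while compound 1 `Cc1ccccc1NC(=O)Nc1cc(C(C)(C)C)nn1-c1ccccc1` gives 7.1 degrees C. The one measured step, a number 6.0 degrees C lower from compound 1 to compound 2 (beyond the scatter), changed both the group and its place on the ring, so it does not bear directly on the next change. Compound 3 `CC(C)(C)c1cc(NC(=O)Nc2ccc(F)cc2)n(-c2ccccc2)n1` differs from compound 2 by fluoro in place of ethoxy on an aromatic carbon. Going by the values given here, no measured step matches this change, so the expected step is uncertain and modest, a number 1.4 degrees C higher from compound 2 to compound 3 (beyond the scatter). Compound 3 is therefore estimated at 2.5 degrees C, within a range from 0 degrees C to 6 degrees C.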

Compound 3, shift of the target's melting temperature: 7.4 degrees C
Compound 3: middle estimate off by 4.9 degrees C, on the low side; measured number above the stated range.
By their numbers in this assay, from the lowest: compound 2; then compounds 1 and 3 (each within the scatter of the next).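

With the rest of the molecule unchanged, the ring place para to a large group responds strongly to its group: fluoro in place of ethoxy gives a number 6.3 degrees C higher from compound 2 to compound 3 (beyond the scatter) in this assay. The low number therefore goes with the 4-ethoxyphenyl group specifically, which the earlier step could not show, since it changed group and place together. The step of a number 0.30 degrees C higher from compound 1 to compound 3 (within the scatter) leaves 4-fluorophenyl and 2-methylphenyl indistinguishable here, and nothing available explains the effect of ethoxy. Open, from the compounds shown here alone, is whether methoxy, a shorter chain, or an amine at this place would give a number near that of compound 2 or of compound 3.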